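Swapping pyridin-4-yl for furan-2-yl in compound 2

The compounds below may be only part of what the source reports. "The series", "measured", "known", "first", "only" and "open" are said of these compounds alone.

Of the compounds shown here, three have been tested in an ADME assay on A549 cells (Homo sapiens) for cytotoxicity, read by MTT assay, with a stated time of 72 h; a lower number here means a stronger inhibitor, a higher number a weaker inhibitor. Compound 1 `Cc1ccc(C(=O)CC2(O)C(=O)Nc3ccc(Nc4ccco4)cc32)cc1` reads > 100000 nM, which is a limit of the assay and not a number. Compound 3 `COC(=O)Nc1ccc2c(c1)/C(=C/c1ccc(Br)cc1)C(=O)N2` reads > 100000 nM, which is also a limit. Among the measured compounds shown here, compound 2 `O=C1Nc2ccc(Br)cc2C1=Cc1ccncc1` gives 22300 nM, the only true number so far. Compound 4 `O=C1Nc2ccc(Br)cc2C1=Cc1ccco1` has not yet been measured. It carries furan-2-yl in place of pyridin-4-yl on a double-bonded chain carbon bound to a double-bonded ring carbon. For the measured compounds named here, no measured pair tests this swap, so only a small shift towards weaker inhibition is expected in this assay, possibly none beyond the scatter. The expected change is a 1.3-fold higher number from compound 2 to compound 4 (0.13 log units; within the scatter). For compound 4 the estimated value is 30000 nM, with an expected range of 10000 nM to 90000 nM.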

Compound 4, half-maximal inhibitory concentration: 449000 nM
Compound 4: the middle estimate sits 15-fold (1.18 log units) below what was measured; the whole stated range lies below it.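

Furan-2-yl in place of pyridin-4-yl on a double-bonded chain carbon bound to a double-bonded ring carbon gives a 20-fold higher number from compound 2 to compound 4 (1.30 log units; beyond the scatter) in this assay. Among the compounds shown here, this is the first pair differing in one place, and it shows that the ring at this place strongly moves the read-out. The number for compound 4 needs care: the limit of > 100000 nM in this assay, at which 2 of the 4 values shown sit.

Still open, from the compounds shown here alone, is whether ring size or the hetero atom accounts for the step. Thiophen-2-yl or pyridin-3-yl at this place would help separate the two.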